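The compounds below may be only part of what the source reports. "The series", "measured", "known", "first", "only" and "open" are said of these compounds alone.

Measured compounds:
Compound 1, `O[C@@H](c1ccccc1)[C@H]1CO[C@H](c2ccccc2)[C@@H](C/C=C/c2ccccc2)C1`, 6060 nM
Compound 2, `COc1cccc(/C=C/C[C@@H]2C[C@@H]([C@@H](O)c3ccc(OC)c(OC)c3)CO[C@H]2c2ccc(OC)c(OC)c2)c1`, 16400 nM

Both numbers come from a functional assay on HeLa cells (Homo sapiens) for cytotoxicity, read by WST assay, with a stated time of 48 h; a lower number here means a stronger inhibitor, a higher number a weaker inhibitor. Compound 1 holds the lowest of the two numbers, and the number for compound 2 lies higher, beyond the usual scatter. Compound 3, `Oc1cccc(/C=C/C[C@H]2C[C@@H]([C@@H](O)c3ccccc3)CO[C@@H]2c2ccccc2)c1`, differs from compound 1 in one place: hydroxy in place of hydrogen on an aromatic carbon. For the measured compounds named here, no pair of measured compounds shows this change on its own, so the data do not fix its direction. The step from compound 1 to compound 3 in this assay is expected to stay within the scatter, a 1.0-fold lower number from compound 1 to compound 3 (0.00 log units; within the scatter). Compound 3 is therefore estimated at 6000 nM in this assay, with a range from 2500 nM to 15000 nM.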

Compound 3, half-maximal inhibitory concentration: 18600 nM
Compound 3: middle estimate off by 3.1-fold (0.49 log units), on the low side, and the stated range ends below it.
By their numbers in this assay, from the lowest: compound 1; then compounds 2 and 3 (each within the scatter of the next).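

In this assay, for the compounds shown here, hydroxy in place of hydrogen on an aromatic carbon gives a 3.1-fold higher number from compound 1 to compound 3 (0.49 log units; beyond the scatter) and so weakens inhibition, which the earlier compounds could not show, as neither offered a single change at this place. On the core of compound 1, then, the 3-phenylprop-2-en-1-yl group does not accept this hydroxy without loss. No measurement at hand accounts for this step. On these data alone, whether an amine or a carboxylic acid on this carbon would give a similar step stays open, as does the outcome of hydroxy on the other phenyl rings.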